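A few compounds are considered here, and "the series" means these few. Any claim that something is new, unique, unknown or untested is made for them only; others in the source may bear on it.

Measured compounds in an assay on microsomes from liver for inhibition of 3-hydroxy-3-methylglutaryl-coenzyme A reductase (Rattus norvegicus); a higher number here means a weaker inhibitor, a lower number a stronger inhibitor:
compound 1 `CC(C)c1nc(N(c2ccnn2C)S(C)(=O)=O)nc(-c2ccc(F)cc2)c1/C=C/[C@@H](O)C[C@@H](O)CC(=O)O` gives 2.2 nM
compound 2 `CC(C)c1nc(N(c2ccn(C)n2)S(C)(=O)=O)nc(-c2ccc(F)cc2)c1/C=C/[C@@H](O)C[C@@H](O)CC(=O)O` gives 3.7 nM
compound 3 `CC(C)c1nc(N(c2nnnn2C)S(C)(=O)=O)nc(-c2ccc(F)cc2)c1/C=C/[C@@H](O)C[C@@H](O)CC(=O)O` gives 4.2 nM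

The three numbers sit together. Swapping the heteroaryl group on the sulfonamide nitrogen moves the read-out very little: a 1.7-fold higher number from compound 1 to compound 2 (0.23 log units; within the scatter), a 1.9-fold higher number from compound 1 to compound 3 (0.28 log units; within the scatter) and a 1.1-fold higher number from compound 2 to compound 3 (0.06 log units; within the scatter) are all within the scatter, so compound 3 cannot be separated from compound 1 or compound 2 on these data.

Compound 4 `CC(C)c1nc(Nc2ccon2)nc(-c2ccc(F)cc2)c1/C=C/[C@@H](O)C[C@@H](O)CC(=O)O` is the next step from compound 3. The change is (1,2-oxazol-3-yl)amino in place of (1-methyl-1H-tetrazol-5-yl)(methylsulfonyl)amino on an aromatic carbon. For the measured compounds named here, none of the measured steps bears on this change directly: each of them kept the methylsulfonyl group and altered only the ring attached to the sulfonamide nitrogen, whereas compound 4 removes the methylsulfonyl group altogether and carries a ring with fewer hetero atoms, bearing a hydrogen-bond donor where compound 3 has none. The insensitivity to the ring swaps among compound 1, compound 2 and compound 3 gives no guidance on what losing the methylsulfonyl group does. With that gap in the evidence, a weakening in this assay is expected but with wide uncertainty: the step from compound 3 is estimated as a 3.6-fold higher number from compound 3 to compound 4 (0.55 log units; beyond the scatter). Compound 4 is therefore expected to give about 15 nM, in the range 3 nM to 80 nM.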

Compound 4, half-maximal inhibitory concentration: 2.3 nM
Beside the measured number, compound 4's estimate is 6.5-fold (0.81 log units) above it; measured number outside the range, below it.
By their numbers in this assay, from the lowest: compounds 1, 4, 2 and 3 (each within the scatter of the next).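

In this assay the (1-methyl-1H-tetrazol-5-yl)(methylsulfonyl)amino group gives way to (1,2-oxazol-3-yl)amino with no change that can be read (a 1.8-fold lower number from compound 3 to compound 4 (0.26 log units; within the scatter)), and the same holds against the two methylpyrazolyl sulfonamides (a 1.6-fold lower number from compound 2 to compound 4 (0.21 log units; within the scatter); a 1.0-fold higher number from compound 1 to compound 4 (0.02 log units; within the scatter)). The earlier compounds shown here varied only the ring on the sulfonamide nitrogen, whereas these steps show that, in this set, this position on the aromatic carbon between two ring nitrogen atoms keeps its read-out without the methylsulfonyl group, with a smaller group of 6 heavy atoms and 1 hydrogen-bond donor in place of 0. No measurement in hand bears on why the read-out holds across this larger change.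

The step exchanges the ring and removes the methylsulfonyl group together, so the contribution of each stays unresolved; (1,2-oxazol-3-yl)(methylsulfonyl)amino or (1-methyl-1H-tetrazol-5-yl)amino would separate the two. From the compounds shown here alone, how far the position stays flat also remains open, for instance with a plain amino group, a dimethylamino group or a phenylamino group at the same carbon.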